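This account rests on a few compounds, and the source may have more. Where it says the series, first, only, none or still open, it means among the compounds named here.

Measured so far:
- compound 1 `COC1=C(C)C(=O)/C(=C(O)/C=C/c2ccc(Br)cc2)C(=O)C1(C)C`: < 4 ug/mL
- compound 2 `COC1=C(C)C(=O)/C(=C(O)/C=C/c2c(C)cccc2C)C(=O)C1(C)C`: < 4 ug/mL

All the data come from a functional assay on HUVEC cells (Homo sapiens); on this read-out lower numbers stand for an effect already at smaller amounts and higher numbers for an effect only at larger amounts of compound. Compound 2 gives < 4 ug/mL, which is a limit and not a number. Compound 1 gives < 4 ug/mL, which is also a limit. Neither compound therefore has an exact position on the scale, and the evidence so far comes down to the limit of < 4 ug/mL in this assay, at which 2 of the 2 values shown sit.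

The next compound is compound 3 `COC1=C(C)C(=O)/C(=C(O)/C=C/c2nccs2)C(=O)C1(C)C`. In it, 1,3-thiazol-2-yl takes the place of 2,6-dimethylphenyl on a double-bonded chain carbon bound to a double-bonded chain carbon: 1,3-thiazol-2-yl in place of 2,6-dimethylphenyl on a double-bonded chain carbon bound to a double-bonded chain carbon. Going by the values given here, the only measured step at this place is a step that the two limits leave unreadable from compound 1 to compound 2. It bears directly on the change, but its size cannot be read, so it offers no measured size or direction to carry over. The new group is also a different kind of ring from either group tested so far, so the expectation remains loose. Compound 3 is expected to remain close to the limit reached by the other two compounds.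

The expected change is a step that the limit leaves unreadable from compound 2 to compound 3, an estimate with no firm direction behind it.

Compound 3 is estimated at 2 ug/mL, with an expected range from 0.5 ug/mL to 8 ug/mL.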

Compound 3, concentration for half-maximal effect: < 4 ug/mL
Compound 3 ended at the assay's limit; the forecaster's own chance of this, stated with the estimate: 65%; the middle value is on the limit's open side.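

No step among compound 1, compound 2 and compound 3 can be read, since in this assay all three end at a limit and not at a number: the limit of < 4 ug/mL in this assay, at which 3 of the 3 values shown sit.

The compounds shown leave open how far apart the three really lie, and whether 4-bromophenyl, 2,6-dimethylphenyl and 1,3-thiazol-2-yl differ in their effect on this read-out at all.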